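Replacing the sulfanyl link of compound 2

The source may report more compounds than this note shows. Statements on the series, on what has been measured and on what is new or still open speak of the compounds shown alone.

Measured so far in a functional assay on the whole organism (strain Hartley) for inhibition, with Cavia porcellus as the target, with stated times of 2 min and 15 min; a lower number here means that less compound is needed, a higher number that more compound is needed for the effect
- compound 1 `CCCCC[C@H](O)/C=C/C1CCC(=O)[C@@H]1CCCCSCC(=O)O` gives 0.00129 mg/kg
- compound 2 `CCCCC(C)(C)[C@H](O)/C=C/C1CCC(=O)[C@@H]1CCCCSCC(=O)O` gives 0.0523 mg/kg

Compound 2 has the higher of the two numbers. Going by the values given here, the only measured step is a 41-fold higher number from compound 1 to compound 2 (1.61 log units; beyond the scatter), which is large but was made at a different place in the structure. Compound 3 `CCCCC(C)(C)[C@H](O)/C=C/C1CCC(=O)[C@@H]1CCCCCCC(=O)O` differs from compound 2 by 2-carboxyethyl in place of (carboxymethyl)sulfanyl on a saturated chain carbon, four bonds along the chain from a saturated ring carbon. Among the compounds with values here, no measured step tests this change, so no shift beyond the scatter is assumed, with wide uncertainty. The expected step is a 1.0-fold lower number from compound 2 to compound 3 (0.02 log units; within the scatter). Compound 3 is estimated at 0.05 mg/kg, with an expected range of 0.012 mg/kg to 0.2 mg/kg.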

Compound 3, dose for half-maximal effect: 0.0259 mg/kg
Beside the measured number, compound 3's estimate is 1.9-fold (0.29 log units) above it; low and high end bracket the measured number.
By their numbers in this assay, from the lowest: compound 1; then compound 3; then compound 2.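

In this assay, going by these compounds alone, 2-carboxyethyl in place of (carboxymethyl)sulfanyl gives a 2.0-fold lower number from compound 2 to compound 3 (0.31 log units; beyond the scatter), the first reading at this place on the chain. On the 1,1-dimethylpentyl background, the sulfur of the chain is therefore not needed for the effect, and an all-carbon link gives a modestly lower dose. No available evidence accounts for this step.

On these data alone, whether the same swap behaves alike with the pentyl group of compound 1 remains open. Also open, as far as these compounds go, are an ether oxygen in place of the sulfur, a longer chain, and a tetrazole in place of the carboxylic acid.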